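The source may report more compounds than this note shows. Statements on the series, on what has been measured and on what is new or still open speak of the compounds shown alone.

Compound 1 `Cc1cc(Br)c(S(C)(=O)=O)cc1C(=O)N=C(N)N` is tested in a functional assay for inhibition of sodium/hydrogen exchanger (Oryctolagus cuniculus) (a lower number here means a stronger inhibitor, a higher number a weaker inhibitor), where compound 1 gives 12 nM. Among the three measured compounds this is the lowest number. Compound 2 `CS(=O)(=O)c1cc(C(=O)N=C(N)N)c(F)cc1F` gives 630 nM, and compound 3 `CCN(CC)Cc1cc(Br)c(S(C)(=O)=O)cc1C(=O)N=C(N)N` gives 9500 nM. Among the compounds with values here, the only measured change in a single place is the step of a 790-fold higher number from compound 1 to compound 3 (2.90 log units; beyond the scatter), in which diethylamino replaces hydrogen on a saturated chain carbon bound to an aromatic carbon. Within the data shown here, compound 2 differs from compound 1 in several places at once, so its gap shows only that compound 2 sits well above compound 1 in this assay.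

Compound 4 `Cc1cc(C2CCCCC2)c(S(C)(=O)=O)cc1C(=O)N=C(N)N` differs from compound 1 by cyclohexyl in place of bromo on an aromatic carbon, ortho to a methylsulfonyl group. Among the measured compounds shown here, no measured step touches that carbon; the step from compound 1 to compound 3 concerns another place and offers little guidance here. Without a close precedent, the expected change in this assay is modest and of uncertain direction. Compound 4 is therefore estimated at 30 nM, within 5 nM to 200 nM, an expected step of a 2.5-fold higher number from compound 1 to compound 4 (0.40 log units; beyond the scatter).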

Compound 4, half-maximal inhibitory concentration: 22 nM
Beside the measured number, compound 4's estimate is 1.4-fold (0.13 log units) above it; low and high end bracket the measured number.
By their numbers in this assay, from the lowest: compounds 1 and 4 (each within the scatter of the next); then compound 2; then compound 3.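

On the aromatic carbon ortho to a methylsulfonyl group, compound 1 and compound 4 cannot be told apart in this assay: the step is a 1.8-fold higher number from compound 1 to compound 4 (0.26 log units; within the scatter), so here a cyclohexyl group of 6 heavy atoms, with its six-membered non-aromatic ring, is tolerated in place of a single bromine atom. The earlier single-place step, a 790-fold higher number from compound 1 to compound 3 (2.90 log units; beyond the scatter), concerns another place and says nothing about this carbon. No measurement shown gives a reason for this result.

From the compounds shown here alone, two groups at one carbon make no general rule, so it remains open whether an amine, a carboxylic acid or a longer chain would be tolerated there as well. Going by these compounds, it is also open whether a phenyl ring, flat where cyclohexyl is not, would give a similar number on the core of compound 1.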